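Triazole thioacetamide oximes: paw edema inhibition notes

The source may report more compounds than this note shows. Statements on the series, on what has been measured and on what is new or still open speak of the compounds shown alone.

Measured so far:
compound 1, `COc1cc(-c2nnc(SCC(=O)Nc3ccc(/C(C)=N/O)cc3)n2-c2ccccc2)cc(OC)c1OC`, 59%
compound 2, `CCn1c(SCC(=O)Nc2ccc(/C(C)=N/O)cc2)nnc1-c1ccc(OC)c(OC)c1`, 53%

In a functional assay on the whole organism (strain albino) for inhibition, with Rattus norvegicus as the target, read by paw edema, with stated times of 30 min and 1 h, at a dose of 0.28 mmol/kg by the oral route (a lower number here means less inhibition, a higher number more inhibition at the dose given (going by the name of the read-out)), compound 2 gives the lower of the two numbers, yet compound 1 sits within the scatter of it, so no order between them can be read. Compound 3, `COc1ccc(-c2nnc(SCC(=O)Nc3ccc(/C(C)=N/O)cc3)n2-c2ccccc2)cc1OC`, has not been measured. It differs from compound 2 in one place: phenyl in place of ethyl on an aromatic nitrogen. Among the measured compounds shown here, no step between measured compounds covers this change. Compound 1 carries the same phenyl and is within the scatter of compound 2, so only a step within the scatter, in either direction, is expected: a number 3 percentage points higher from compound 2 to compound 3 (within the scatter). Compound 3 is estimated at 56%, with a range of 45% to 67%.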

Compound 3, a percentage reported as inhibition, in the whole organism at one dose (the size of the read-out at that dose, not a potency): 57%
Beside the measured number, compound 3's estimate is 1 percentage points below it; the range from low to high includes it.
By their numbers in this assay, from the lowest: compounds 2, 3 and 1 (each within the scatter of the next).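

In this assay, among the compounds shown here, phenyl in place of ethyl on the aromatic nitrogen gives a number 4 percentage points higher from compound 2 to compound 3 (within the scatter), the first direct reading at this position: the larger aromatic ring leaves the number within the scatter. Hydrogen in place of methoxy on an aromatic carbon gives a number 2 percentage points lower from compound 1 to compound 3 (within the scatter), so this second single change also produces no readable shift. No available data explain either step.

On these data alone, whether a longer chain, a benzyl group or an aminoethyl group on that nitrogen would hold the number remains open. A single dose also leaves potency unresolved.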